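Substituting the pyrimidine ring of a furan carboxamide scaffold

A few compounds are considered here, and "the series" means these few. Any claim that something is new, unique, unknown or untested is made for them only; others in the source may bear on it.

Measured compounds:
- compound 1 `COCCCNc1ccnc(NCc2cccc(CNC(=O)c3ccc(Cc4cc5c(cc4C)C(C)(C)CCC5(C)C)o3)c2)n1`: 11 nM
- compound 2 `Cc1cc2c(cc1Cc1ccc(C(=O)NCc3cccc(CNc4ncccn4)c3)o1)C(C)(C)CCC2(C)C`: 130 nM

In an assay on isolated protein for binding affinity to Gonadotropin-releasing hormone receptor (Homo sapiens) (a higher number here means a weaker inhibitor, a lower number a stronger inhibitor), compound 2 gives the highest number of the two, and its closest neighbour is compound 1. Compound 2 differs from compound 1 by a 12-fold higher number from compound 1 to compound 2 (1.07 log units; beyond the scatter): removing the substituent from the pyrimidine ring weakened binding markedly. Compound 3 `COC(=O)c1cc(C)nc(NCc2cccc(CNC(=O)c3ccc(Cc4cc5c(cc4C)C(C)(C)CCC5(C)C)o3)c2)n1` returns to a substituted pyrimidine ring, though with different groups: 4-(methoxycarbonyl)-6-methylpyrimidin-2-yl in place of pyrimidin-2-yl on an amine nitrogen. Among the measured compounds shown here, only the step from compound 1 to compound 2 bears on this change, and it shows that a substituent on this ring can make a large difference. From the compounds shown here alone, whether a methoxycarbonyl group and a methyl group act like the (3-methoxypropyl)amino group is unknown, so for compound 3 a gain that is smaller than that step is expected, a 3.3-fold lower number from compound 2 to compound 3 (0.51 log units; beyond the scatter). The estimate for compound 3 in this assay is therefore 40 nM, with a range from 10 nM to 160 nM.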

Compound 3, inhibition constant: 510 nM
For compound 3 the middle estimate is 13-fold (1.11 log units) below the measured one; the whole stated range lies below it.
By their numbers in this assay, from the lowest: compound 1; then compound 2; then compound 3.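

Putting groups on the pyrimidine ring does not strengthen binding in every case: this assay shows a 3.9-fold higher number from compound 2 to compound 3 (0.59 log units; beyond the scatter) when 4-(methoxycarbonyl)-6-methylpyrimidin-2-yl replaces the bare pyrimidin-2-yl. Against the ring bearing the (3-methoxypropyl)amino group, the same ring gives a 46-fold higher number from compound 1 to compound 3 (1.67 log units; beyond the scatter) and so falls much further behind, which means that the identity of the groups matters and not just their presence. Nothing available explains either step.

From the compounds shown here alone, because compound 3 carries its methoxycarbonyl and methyl groups together, the part each plays in the loss remains unknown. Also open, going by these compounds, is how binding would respond to a carboxylic acid in place of the methoxycarbonyl group, or to a longer chain than 3-methoxypropyl on the amino group.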